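Iodo for ethynyl on a series stuck at limits

The source may hold more compounds than are shown below. What is called first, only, known or untested is meant among the compounds shown, and "the series" means these compounds.

In a functional assay on HCT-116 cells (Homo sapiens), read by MTT assay, with a stated time of 72 h (a lower number here means a stronger inhibitor, a higher number a weaker inhibitor), compound 3 `C#Cc1cn([C@@H]2O[C@H](CO)[C@@H](O)[C@H]2O)c2ncnc(NC)c12` gives only a limit, > 20000 nM. Compound 1 `CNc1ncnc2c1c(-c1ccccc1)cn2[C@@H]1O[C@H](CO)[C@@H](O)[C@H]1O` also gives only a limit, > 100000 nM. Compound 2 `CNc1ncnc2c1c(-c1cc3ccccc3o1)cn2[C@@H]1O[C@H](CO)[C@@H](O)[C@H]1O` likewise gives only a limit, > 20000 nM. Compound 3 therefore sits at the limit of > 20000 nM in this assay, at which 2 of the 3 values shown sit, and no number places it within the series.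

The next compound, compound 4 `CNc1ncnc2c1c(I)cn2[C@@H]1O[C@H](CO)[C@@H](O)[C@H]1O`, carries iodo in place of ethynyl on an aromatic carbon. The exchange lies on the five-membered aromatic ring with 1 nitrogen.

Three measured steps change this same carbon: a step that the two limits leave unreadable from compound 1 to compound 2, a step that the two limits leave unreadable from compound 1 to compound 3 and a step that the two limits leave unreadable from compound 2 to compound 3. None has a readable size, so none can be carried over as a measure for the new exchange. They show only that phenyl, 1-benzofuran-2-yl and ethynyl all end at limits in this assay. On that basis, no clear gain in strength is expected, and compound 4 will most likely also report only a limit.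

The expected change is a step that the limit leaves unreadable from compound 3 to compound 4, an estimate that rests on no readable step and so carries no firm direction. The estimated value for compound 4 is 25000 nM, within an expected range of 5000 nM to 100000 nM.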

Compound 4, half-maximal inhibitory concentration: > 100000 nM
Compound 4: no number, only a limit (the forecaster's own chance of this, stated with the estimate: 75%); at least 4.0-fold (0.60 log units) between middle value and limit.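

Compound 4 gives only a limit in this assay, > 100000 nM, so its steps from compound 1, compound 2 and compound 3 cannot be read. With all four compounds at limits, the compounds shown leave open how phenyl, 1-benzofuran-2-yl, ethynyl and iodo rank on this aromatic carbon, and whether any group there gives a readable value in this assay.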